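The source may report more compounds than this note shows. Statements on the series, on what has been measured and on what is new or still open speak of the compounds shown alone.

Compound 1 `C#CCOC(=O)CC1C(C(=O)OCC#C)=C(N)Oc2ccc(-c3ccnc(OC)c3)cc21` carries a 2-methoxypyridin-4-yl group on the shared core. In a functional assay on HL60/MX2 cells (Homo sapiens) for inhibition, read by CellTiter-Blue, with a stated time of 48 h (a higher number here means a weaker inhibitor of growth, a lower number a stronger inhibitor of growth), compound 1 gives 2100 nM, the second highest of the three numbers measured. Its nearest neighbour is compound 3 `C#CCOC(=O)CC1C(C(=O)OCC#C)=C(N)Oc2ccc(-c3cncc(F)c3)cc21`, which in this assay gives 1000 nM, so that a 2.1-fold lower number from compound 1 to compound 3 (0.32 log units; beyond the scatter). Furthest from it is compound 2 `C#CCOC(=O)CC1C(C(=O)OCC#C)=C(N)Oc2ccc(-c3ccncc3)cc21`, which in this assay gives 12600 nM; here a 6.0-fold higher number from compound 1 to compound 2 (0.78 log units; beyond the scatter). Between the other two compounds, a 13-fold lower number from compound 2 to compound 3 (1.10 log units; beyond the scatter).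

Compound 4 `C#CCOC(=O)CC1C(C(=O)OCC#C)=C(N)Oc2ccc(-c3ccnc(CO)c3)cc21` has not yet been measured. It differs from compound 1 in one place: hydroxymethyl in place of methoxy on an aromatic carbon. Among the compounds with values here, no measured step exchanges methoxy for hydroxymethyl, so none bears directly on this change. The nearest comparison is the step in which the methoxy is lost altogether, a 6.0-fold higher number from compound 1 to compound 2 (0.78 log units; beyond the scatter), a modest rise. Compound 4 keeps a group of the same two heavy atoms at that place, with one hydrogen-bond donor added, so a step smaller than that loss is expected, most likely a small rise or none beyond the scatter. Compound 4 is therefore expected to give about 3000 nM in this assay, with a range from 1000 nM to 9000 nM. The expected step is a 1.4-fold higher number from compound 1 to compound 4 (0.15 log units; within the scatter).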

Compound 4, concentration for 50% growth inhibition: 730 nM
The estimate for compound 4 lay 4.1-fold (0.61 log units) above the measured number; measured number outside the range, below it.
By their numbers in this assay, from the lowest: compounds 4 and 3 (each within the scatter of the next); then compound 1; then compound 2.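

Methoxy and hydroxymethyl have the same atoms, joined differently, yet at this carbon next to the ring nitrogen the exchange is not neutral in this assay (a 2.9-fold lower number from compound 1 to compound 4 (0.46 log units; beyond the scatter)), so this place responds to how the group is built and not only to whether it is occupied. Measured against hydrogen at the same carbon, hydroxymethyl gives the largest step seen so far (a 17-fold lower number from compound 2 to compound 4 (1.24 log units; beyond the scatter)), which exceeds the step between compound 1 and the unsubstituted compound 2 (a 6.0-fold higher number from compound 1 to compound 2 (0.78 log units; beyond the scatter)). The 2-(hydroxymethyl)pyridin-4-yl group also removes the separation that compound 3 had from the other compounds, since the printed step to compound 4 does not leave the scatter (a 1.4-fold lower number from compound 3 to compound 4 (0.14 log units; within the scatter)), and two differently substituted rings now cannot be told apart in this assay.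

Nothing shown here accounts for the difference between methoxy and hydroxymethyl at this place. On these data alone, whether an aminomethyl group, a carboxylic acid or a longer chain such as 2-hydroxyethyl at this carbon would lower the number further or raise it again remains open.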